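Trimming the ethyl on a shared core

The source may hold more compounds than are shown below. What is called first, only, known or untested is meant among the compounds shown, and "the series" means these compounds.

Measured in a functional assay for inhibition, with Homo sapiens as the target; a higher number here means a weaker inhibitor, a lower number a stronger inhibitor:

- compound 1, `CCCc1nc(C)c2c(CC)nnc(SC)n12`: > 48000 nM, a limit of the assay
- compound 2, `CCCc1nc(C)c2c(CC)nnc(S)n12`: > 48000 nM, a limit of the assay
- compound 3, `CCc1nnc(S)n2c(C(C)CC)nc(C)c12`: > 48000 nM, a limit of the assay

Compound 2 thus stands at no number at all, only at a limit, and it does so together with its two neighbours, since (the limit of > 48000 nM in this assay, at which 3 of the 3 values shown sit). The two one-place changes that connect these compounds give nothing readable: the step that the two limits leave unreadable from compound 1 to compound 2 and the step that the two limits leave unreadable from compound 2 to compound 3, both of them hidden because both ends sit at the limit of > 48000 nM in this assay, at which 3 of the 3 values shown sit.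

Compound 4 `CCCc1nc(C)c2c(C)nnc(S)n12` differs from compound 2 by hydrogen in place of methyl on a saturated chain carbon bound to an aromatic carbon. The closest measured step, the one with a methyl on a saturated chain carbon between compound 2 and compound 3, is unreadable, so no direction and no size can be taken from it. With every measured value at the same limit, the expectation for the step from compound 2 to compound 4 in this assay is a step that the limit leaves unreadable from compound 2 to compound 4, most likely again invisible behind the limit. Compound 4 is therefore estimated at 70000 nM, with a range from 20000 nM to 300000 nM, and will probably be reported only as a limit.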

Compound 4, half-maximal inhibitory concentration: 45000 nM
For compound 4 the middle estimate is 1.6-fold (0.19 log units) above the measured one, within the range that was stated.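

Trimming ethyl to methyl at this place, on a saturated chain carbon bound to an aromatic carbon, gives the series its first real number: in this assay compound 4 is the only compound shown that reads as a value and not as a limit. The change gives an at least 1.0-fold lower number from compound 2 to compound 4 (0.02 log units; that floor lies within the scatter), and that floor says only that the step is not shown to be large, while its true size stays hidden, since the starting point is a limit and not a number. So this position can be read at all once it carries methyl, yet the value still lies in the same region as the ceiling that holds the other compounds: the limit of > 48000 nM in this assay, at which 3 of the 4 values shown sit.

The compounds shown leave open whether the number would keep moving with a further change at this place, for example hydrogen in place of the methyl, or an amine or a carboxylic acid there. They also leave open whether the methyl on sulfur, which cannot be judged from limits alone, would matter on a core that carries methyl at this place, and whether a longer chain such as butyl in the propyl position would shift the value.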